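The source may report more compounds than this note shows. Statements on the series, on what has been measured and on what is new or still open speak of the compounds shown alone.

In a functional assay on Huh-7 cells (Homo sapiens) for antiproliferative activity, read by sulforhodamine B assay, with a stated time of 72 h (a higher number here means a weaker inhibitor, a lower number a stronger inhibitor), compound 1 (`OC[C@H]1O[C@@H](n2cnc3c(N4CCN(c5ncccn5)CC4)ncnc32)[C@H](O)[C@@H]1O`) reads "not active" (no number reported) and compound 2 (`CSc1ccc(Nc2ncnc3c2ncn3[C@@H]2O[C@H](CO)[C@@H](O)[C@H]2O)cc1`) reads "not active" (no number reported) with no number given. Among the compounds with values here, compound 3 (`CC(C)c1ccc(Nc2ncnc3c2ncn3[C@@H]2O[C@H](CO)[C@@H](O)[C@H]2O)cc1`) gives 60000 nM as the only number, so no measured step is available as a guide. Compound 4 (`OC[C@H]1O[C@@H](n2cnc3c(NCCC4=CCCCC4)ncnc32)[C@H](O)[C@@H]1O`) has 2-(cyclohex-1-en-1-yl)ethyl in place of 4-isopropylphenyl on a nitrogen on an aromatic ring. The expected change a 1.2-fold lower number from compound 3 to compound 4 (0.08 log units; within the scatter) stays within the usual scatter of this assay and no direction is favoured. A reading like that of compound 2 at "not active" (no number reported) also remains possible for compound 4. For compound 4 the estimated value is 50000 nM with an expected range from 15000 nM to 150000 nM if a number is reported at all.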

Compound 4, half-maximal inhibitory concentration: > 100000 nM
Compound 4: only a limit was reported; the forecaster's own chance of this, stated with the estimate: 45%; middle value at least 2.0-fold (0.30 log units) away from the limit.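

In this assay compound 4 reads > 100000 nM, a limit of the assay and not a number. The step reads an at least 1.6-fold higher number from compound 3 to compound 4 (0.22 log units; that floor lies within the scatter), so 2-(cyclohex-1-en-1-yl)ethyl in place of 4-isopropylphenyl on a nitrogen on an aromatic ring brings no gain, though the size of the change stays unresolved. The reading gives only a floor: the limit of > 100000 nM in this assay, at which 1 of the 4 values shown sits.

Compound 1 and compound 2 carry no number, so steps involving them cannot be read. From the compounds shown here alone, whether an amine or a carboxylic acid on the group at this nitrogen would give a stronger reading in this assay remains open.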